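Trading a Methoxyphenyl for a Furan Ring

The source may hold more compounds than are shown below. What is called first, only, known or untested is meant among the compounds shown, and "the series" means these compounds.

Compound 1 `Cc1c(C(=O)N/N=C\c2cc(O)ccc2O)oc2cccc(O)c12` gives 95500 nM in a functional assay on PC-3 cells (Homo sapiens) for inhibition; on this read-out higher numbers stand for weaker inhibition and lower numbers for stronger inhibition. Compound 2 `Cc1ccc(O)c(/C=N\NC(=O)c2oc3cccc(O)c3c2C)c1` gives 7350 nM, and the change is a 13-fold lower number from compound 1 to compound 2 (1.11 log units; beyond the scatter). Compound 3 `COc1cccc(/C=N\NC(=O)c2oc3cccc(O)c3c2C)c1` carries a 3-methoxyphenyl group on the carbon with a double bond to nitrogen. For compound 3 only a limit is recorded, >= 40000 nM. Against compound 2 this is an at least 5.4-fold higher number from compound 2 to compound 3 (0.73 log units; beyond the scatter), while the comparison with compound 1 is a step that the limit leaves unreadable from compound 1 to compound 3, so compound 3 stands at the weak end of the three, at the limit (the limit of >= 40000 nM in this assay, at which 1 of the 3 values shown sits).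

Compound 4 `Cc1c(C(=O)N/N=C\c2ccco2)oc2cccc(O)c12` is the next step: furan-2-yl in place of 3-methoxyphenyl on a carbon with a double bond to nitrogen. Going by the values given here, both the group that leaves and the group that enters lack a hydroxy group, and the one measured step that bears on this change, an at least 5.4-fold higher number from compound 2 to compound 3 (0.73 log units; beyond the scatter), ran toward weaker inhibition when the hydroxy-bearing ring was given up. The step that the limit leaves unreadable from compound 3 to compound 4 is therefore expected to stay within the scatter, with compound 4 estimated at 60000 nM, ranging from 15000 nM to 200000 nM, and a limit is a likely outcome for compound 4 as well.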

Compound 4, half-maximal inhibitory concentration: >= 40000 nM
Compound 4 was reported as a limit; the forecaster's own chance of this, stated with the estimate: 60%; the middle value does not contradict the limit.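

In this assay compound 4 is also recorded only as a limit, so a second ring without a hydroxy group on the carbon with a double bond to nitrogen ends in the same place as compound 3: the limit of >= 40000 nM in this assay, at which 2 of the 4 values shown sit. The furan-2-yl group in place of 2-hydroxy-5-methylphenyl gives an at least 5.4-fold higher number from compound 2 to compound 4 (0.73 log units; beyond the scatter), which shows that the gap to compound 2 is not confined to the 3-methoxyphenyl group. The steps from compound 3 to compound 4 and from compound 1 to compound 4 cannot be read, and compound 1 goes against any simple link between a hydroxy group and stronger inhibition, since it carries one and gives 95500 nM.

On these data alone, it remains open whether the hydroxy group or the methyl group on the ring of compound 2 matters more for its 7350 nM. As far as these compounds go, how a 2-hydroxyphenyl group, or a ring bearing an amine or a carboxylic acid, would read at this place also stays open.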